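A few compounds are considered here, and "the series" means these few. Any claim that something is new, unique, unknown or untested is made for them only; others in the source may bear on it.

Compound 2 `c1cncc(OC[C@]23C[C@H]2CCN3)c1` and compound 1 `Clc1ccc(OC[C@]23C[C@H]2CCN3)cn1` share one core and differ in a single spot: chloro in place of hydrogen on an aromatic carbon. In an assay on CHO-K1 cells for displacement of a labelled ligand from Neuronal acetylcholine receptor; alpha4/beta2 (Homo sapiens), read by scintillation counting (a higher number here means a weaker inhibitor, a lower number a stronger inhibitor), compound 2 gives 242 nM, and compound 1 gives 341 nM, a step of a 1.4-fold higher number from compound 2 to compound 1 (0.15 log units; within the scatter). Compound 3 `C[C@@]12C[C@@H]1CC(COc1cccnc1)N2` has a different core; how its core differs from that of compound 2 is not broken down here. In this assay compound 3 gives 3.6 nM, the lowest of the three numbers. Compound 4 `C[C@@]12C[C@@H]1CC(COc1ccc(Cl)nc1)N2` carries the same kind of change on the core of compound 3: chloro in place of hydrogen on an aromatic carbon. The two places differ only in the size of the group para to the entering chloro, as the two counted differences show. Because the earlier step of a 1.4-fold higher number from compound 2 to compound 1 (0.15 log units; within the scatter) lay within the scatter, the step from compound 3 to compound 4 is expected to be small too, a 1.4-fold higher number from compound 3 to compound 4 (0.14 log units; within the scatter). Compound 4 is therefore estimated at 5 nM.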

Compound 4, inhibition constant: 6880 nM
Compound 4: the middle estimate sits 1400-fold (3.14 log units) below what was measured, outside the stated range (above it).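

The same change, chloro in place of hydrogen on an aromatic carbon, does not give the same result on both cores in this assay: the same change on two cores in this assay, a 1.4-fold higher number (0.15 log units; within the scatter) from compound 2 to compound 1 and a 1900-fold higher number (3.28 log units; beyond the scatter) from compound 3 to compound 4, 1400-fold (3.13 log units) apart, beyond the scatter of two such steps. Here the change gave a 1900-fold higher number from compound 3 to compound 4 (3.28 log units; beyond the scatter), whereas on the other core it stayed within the scatter, so the small step on one core was no guide to the step on the other. These two pairs show that the size of this step can differ between cores in this series, but they do not show why, and they set no rule for any further core.

The compounds shown leave open whether fluoro, methyl or an amine at the same place on the core of compound 3 would give a step as large as chloro. They also leave open which difference between the two cores goes with the large step.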